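Carrying a Chloro Step from One Core to Another

The compounds below may be only part of what the source reports. "The series", "measured", "known", "first", "only" and "open" are said of these compounds alone.

Compound 1 `O=C(Nc1ccccn1)c1cc2n(n1)CCCC2` gives 364 nM in a functional assay on HEK293 cells for negative allosteric modulation of metabotropic glutamate receptor 5 (Rattus norvegicus), read by FLIPR and calcium flux, with a stated time of 170 s; a higher number here means a weaker inhibitor, a lower number a stronger inhibitor. Compound 2 `O=C(Nc1ccc(Cl)cn1)c1cc2n(n1)CCCC2` gives 262 nM in this assay; it differs by chloro in place of hydrogen on an aromatic carbon, and the step was a 1.4-fold lower number from compound 1 to compound 2 (0.14 log units; within the scatter). Compound 3 `c1ccc(-c2cc3n(n2)CCCC3)cc1` gives 1900 nM in this assay, the highest of the three numbers; how its core differs from that of compound 1 is not broken down here. Compound 4 `Clc1ccc(-c2cc3n(n2)CCCC3)cc1` is unmeasured and differs from compound 3 by chloro in place of hydrogen on an aromatic carbon. This is the same kind of change as before, but the place differs: in compound 2 the chloro sits on a ring with 1 nitrogen, two atoms from the ring nitrogen, para to a large group, while in compound 4 it sits on a ring of carbon only, para to a group of 9 heavy atoms. Because the earlier step was a 1.4-fold lower number from compound 1 to compound 2 (0.14 log units; within the scatter), a small step is expected, a 1.5-fold lower number from compound 3 to compound 4 (0.16 log units; within the scatter). Compound 4 is therefore estimated at 1300 nM, between 500 nM and 3500 nM.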

Compound 4, half-maximal inhibitory concentration: 4230 nM
Compound 4: middle estimate off by 3.3-fold (0.51 log units), on the low side, outside the stated range (above it).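

In this assay, chloro in place of hydrogen on an aromatic carbon gave a 2.2-fold higher number from compound 3 to compound 4 (0.35 log units; beyond the scatter), and this step does not match the one seen on the other core: the same change on two cores in this assay, a 1.4-fold lower number (0.14 log units; within the scatter) from compound 1 to compound 2 and a 2.2-fold higher number (0.35 log units; beyond the scatter) from compound 3 to compound 4, 3.1-fold (0.49 log units) apart, beyond the scatter of two such steps. In this series, then, the size of the step on one core was no reliable guide to its size on the other. Among these compounds, this does not show why the steps differ, as the two pairs differ both in the core and in the ring carrying the chloro, and each core supplies only one pair.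

The compounds shown leave open how fluoro, methoxy or a nitrile at the same place would behave on either core. They also leave open whether an amine there would show the same gap between cores.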